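The compounds below may be only part of what the source reports. "The series", "measured", "known", "first", "only" and "open" are said of these compounds alone.

Of the compounds shown here, three share one core and have been measured in an assay on isolated protein for inhibition of 2-Hydroxyacid oxidase 2 (Homo sapiens), tested at 10 uM; a lower number here means a weaker effect, a higher number a stronger effect of the compound at the concentration tested. Compound 2 `Cc1n[nH]c(C(=O)O)c1Cc1cccc(-c2ccc(C#N)cc2)c1` gives 46% in this assay, the highest of the three numbers. Compound 1 `Cc1n[nH]c(C(=O)O)c1Cc1cccc(-c2ccc(OC(F)(F)F)cc2)c1` gives 34%, and compound 3 `Cc1n[nH]c(C(=O)O)c1Cc1cccc(C(F)(F)F)c1` gives 23%. Both gaps to compound 2 lie beyond the scatter: a number 12 percentage points higher from compound 1 to compound 2 (beyond the scatter) and a number 23 percentage points lower from compound 2 to compound 3 (beyond the scatter).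

Compound 4 `Cc1n[nH]c(C(=O)O)c1Cc1cccc(-c2ccc(C(F)(F)F)cc2)c1` is not yet measured in this assay. It differs from compound 2 in one place: trifluoromethyl in place of cyano on an aromatic carbon.

Among the measured compounds shown here, of the two measured steps, the one from compound 1 to compound 2 bears most directly on this change, since it also exchanged cyano against a fluorine-bearing group on the same aromatic carbon, and there cyano in place of trifluoromethoxy gave a number 12 percentage points higher from compound 1 to compound 2 (beyond the scatter). The step from compound 2 to compound 3 replaced the whole 4-cyanophenyl by trifluoromethyl, a number 23 percentage points lower from compound 2 to compound 3 (beyond the scatter), and so speaks only loosely to an exchange within the distal ring. Reversing the direction of the first step, trifluoromethyl in place of cyano is expected to cost inhibition, by a step of about a number 16 percentage points lower from compound 2 to compound 4 (beyond the scatter), modest but beyond the scatter.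

Compound 4 is therefore estimated at 30% in this assay, within a range from 15% to 45%.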

Compound 4, a percentage reported as inhibition, at one concentration (the size of the read-out at that concentration, not a potency): 30%
The estimate for compound 4 equals the measured number at the digits printed, and the stated range covers the measured number.
By their numbers in this assay, from the lowest: compounds 3, 4 and 1 (each within the scatter of the next, the first and the last beyond it); then compound 2.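

With trifluoromethyl as well as trifluoromethoxy now tested on this aromatic carbon, para to a large group, the nitrile of compound 2 is set apart from a second fluorine-bearing group in this assay: there is a number 16 percentage points lower from compound 2 to compound 4 (beyond the scatter). The exchange between the two fluorine-bearing groups itself gives a number 4 percentage points lower from compound 1 to compound 4 (within the scatter), so compounds 1 and 4 cannot be told apart here, and the extra oxygen of trifluoromethoxy shows no readable effect on this read-out. Among the three compounds that differ only at this carbon, compound 2 alone stands clear of the others, although nothing available explains this difference.

On these data alone, whether a primary carboxamide, a methoxy group or a chlorine atom on this carbon would group with the nitrile or with the two fluorine-bearing groups remains open, as does whether any such group would surpass compound 2, which stands at 46%. Also open, as far as these compounds go, is whether the nitrile keeps its place in the order once the methyl group or the carboxylic acid of the shared core is replaced, for instance by an ethyl group or a tetrazole.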